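A few compounds are considered here, and "the series" means these few. Any claim that something is new, unique, unknown or untested is made for them only; others in the source may bear on it.

Measured in a functional assay on MKN-45 cells (Homo sapiens) for inhibition, with a stated time of 72 h; a higher number here means a weaker inhibitor, a lower number a stronger inhibitor:
- compound 1 `COc1cc(C(=O)c2cccc3[nH]ccc23)cc(OC)c1OC`: 49.1 nM
- compound 2 `COc1cc(C(=O)c2ccc3c(ccn3C)c2)cc(OC)c1OC`: 11.2 nM

Compound 2, at 11.2 nM, has the lower number of the pair, and its gap to compound 1 lies beyond the usual scatter. Compound 3 `COc1cc(C(=O)c2ccc3c(ccn3CCN(C)C)c2)cc(OC)c1OC` differs from compound 2 by (dimethylamino)methyl in place of hydrogen on a saturated chain carbon bound to an aromatic nitrogen, which also reads as methyl to 2-(dimethylamino)ethyl. Among the measured compounds shown here, no measured pair shows this change, so only a tentative expectation is possible. In this assay a small rise in the number is expected, about the size of the usual scatter, a 1.8-fold higher number from compound 2 to compound 3 (0.25 log units; within the scatter). The estimated value for compound 3 is 20 nM, with an expected range of 6 nM to 70 nM.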

Compound 3, half-maximal inhibitory concentration: 2900 nM
The estimate for compound 3 lay 150-fold (2.16 log units) below the measured number; the measured number lies above the stated range.
By their numbers in this assay, from the lowest: compound 2; then compound 1; then compound 3.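

In this assay, replacing hydrogen with (dimethylamino)methyl on a saturated chain carbon bound to an aromatic nitrogen gave a 260-fold higher number from compound 2 to compound 3 (2.41 log units; beyond the scatter) and made compound 3 the weakest of the three compounds. This position, which carries only methyl in compound 2, therefore proved highly sensitive to this extension. Nothing available explains the loss.

On these data alone, whether the loss follows the amine or the longer chain itself remains open. A plain propyl chain, a 2-hydroxyethyl group or a morpholine on the same chain would help separate the two.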